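This account rests on a few compounds, and the source may have more. Where it says the series, first, only, none or still open, it means among the compounds named here.

Compounds with measured values:
- compound 1 `Cc1ccccc1-n1nc(C)c2c1NC(=O)[C@H](C)S[C@@H]2c1ccc(-c2cccc(C(=O)O)c2)cc1`: "not active" (no number reported)
- compound 2 `Cc1ccccc1-n1nc(C)c2c1NC(=O)[C@H](C)S[C@@H]2c1ccc(-c2cc3ccccc3o2)cc1`: 1500 nM
- compound 3 `Cc1ccccc1-n1nc(C)c2c1NC(=O)[C@H](C)S[C@@H]2c1ccc(-c2ccco2)cc1`: 3600 nM

In an assay on isolated protein for agonist activity at Bile acid receptor (Homo sapiens), read by AlphaScreen, with a stated time of 30 min (on this read-out lower numbers stand for an effect already at smaller amounts and higher numbers for an effect only at larger amounts of compound), compound 3 gives the highest of the two numbers; its nearest neighbour is compound 2, from which the step of a 2.4-fold higher number from compound 2 to compound 3 (0.38 log units; beyond the scatter) is modest. Compound 1, with a carboxylic acid on the outer ring, shows no activity at all. Compound 4 `Cc1ccccc1-n1nc(C)c2c1NC(=O)[C@H](C)S[C@@H]2c1ccc(Oc2ccc(C(=O)O)cc2)cc1` differs from compound 3 in this way: 4-carboxyphenoxy in place of furan-2-yl on an aromatic carbon. Among the measured compounds shown here, no measured step covers this change directly; the step from compound 2 to compound 3 concerns only the size of the oxygen-bearing ring. For the measured compounds named here, the only compound carrying a carboxylic acid, compound 1, gives "not active" (no number reported) in this assay, so a weaker effect is expected for compound 4, with a fair chance of no number at all. Compound 4 is therefore estimated at 15000 nM (range 4000 nM to 60000 nM), a step of a 4.2-fold higher number from compound 3 to compound 4 (0.62 log units; beyond the scatter) expected in the direction of a larger number.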

Compound 4, half-maximal effective concentration: "not active" (no number reported)
For compound 4 the study gives words and no number, and the estimate cannot be compared.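

Compound 4 gives no number in this assay, so no step from compound 3 to compound 4 can be read, and no measurement shown here accounts for this result. The compounds shown leave open whether any outer group carrying a carboxylic acid can give a measurable effect.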